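Ring Replaced by a Chain at the Aromatic Carbon

This account rests on a few compounds, and the source may have more. Where it says the series, first, only, none or still open, it means among the compounds named here.

Measured compounds:
compound 1, `CC(=O)N1CCN(c2cncc(N3C(=O)c4ccc(Cl)cc4C3(C)C)c2)CC1`, in an assay on cells for inhibition of cytochrome P450 11B2, mitochondrial (Homo sapiens), read by HTRF (a higher number here means a weaker inhibitor, a lower number a stronger inhibitor), compound 1 gives 9 nM
compound 2, `CC(=O)N1CCC(c2cncc(N3C(=O)c4ccc(Cl)cc4C3(C)C)c2)CC1`, compound 2 gives 5 nM
compound 3, `CC(=O)N1CC[C@H](Oc2cncc(N3C(=O)c4ccc(Cl)cc4C3(C)C)c2)C1`, compound 3 gives 7 nM

Compound 3 stands second highest of the three numbers. Its nearest neighbour is compound 1, and the step of a 1.3-fold lower number from compound 1 to compound 3 (0.11 log units; within the scatter) lies within the scatter; the step of a 1.4-fold higher number from compound 2 to compound 3 (0.15 log units; within the scatter) is also within the scatter, as is a 1.8-fold lower number from compound 1 to compound 2 (0.26 log units; within the scatter). All three measured compounds are therefore indistinguishable in this assay.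

Compound 4, `CC1(C)c2cc(Cl)ccc2C(=O)N1c1cncc(CNS(C)(=O)=O)c1`, differs from compound 3 at the same aromatic carbon: a group of 6 heavy atoms (2 carbon, 1 nitrogen, 2 oxygen, 1 sulfur; no ring) in place of a group of 9 heavy atoms (6 carbon, 1 nitrogen, 2 oxygen; one five-membered non-aromatic ring with 1 hetero atom), on an aromatic carbon. The position is two atoms from the ring nitrogen. The measured steps all exchange one saturated ring for another at this carbon and none of them moves the number beyond the scatter. The change to compound 4 goes further, removing the ring altogether and bringing in a hydrogen-bond donor, so those steps bear on it only loosely. The step of a 2.1-fold higher number from compound 3 to compound 4 (0.33 log units; beyond the scatter) is expected to be small, with a slight lean toward a weaker inhibitor but possibly none beyond the scatter. Compound 4 is therefore estimated at 15 nM, in the range 4 nM to 60 nM.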

Compound 4, half-maximal inhibitory concentration: 33 nM
Estimate against measurement, compound 4: 2.2-fold (0.34 log units) below, and the stated range covers the measured number.
By their numbers in this assay, from the lowest: compounds 2, 3 and 1 (each within the scatter of the next); then compound 4.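

In this assay, this aromatic carbon, two atoms from the ring nitrogen, turns out not to accept every group alike: the (methanesulfonamido)methyl group gives a 4.7-fold higher number from compound 3 to compound 4 (0.67 log units; beyond the scatter) and a 6.6-fold higher number from compound 2 to compound 4 (0.82 log units; beyond the scatter) and a 3.7-fold higher number from compound 1 to compound 4 (0.56 log units; beyond the scatter) as well, all of them beyond the scatter. Among these compounds, the exchanges among the three saturated ring groups had stayed within the scatter, so the earlier compounds gave no sign that a substituent here could move the number at all, whereas this open chain with a hydrogen-bond donor does so, though each step is only modest. No evidence is at hand that would explain this shift or separate the loss of the ring from the gain of the donor.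

The compounds shown leave open which of those two changes matters, since both occur together in compound 4. A 1-(methanesulfonyl)piperidin-4-yl group would keep the ring while carrying the sulfonyl group, a chain with a methyl group on the sulfonamide nitrogen would lack the sulfonamide hydrogen, and an amine or a carboxylic acid at this carbon remains an open case too.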